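The source may hold more compounds than are shown below. What is called first, only, known or untested is meant among the compounds shown, and "the series" means these compounds.

Measured compounds in a functional assay on cells (T-cell line, Homo sapiens) for inhibition; a lower number here means a stronger inhibitor, a higher number a weaker inhibitor:
compound 1 `COc1ccc(CCCN2CCC(COCc3ccccn3)CC2)cc1` — 5900 nM
compound 2 `Cc1ccc(CCCN2CCC(COC(c3ccccc3)c3ccccc3)CC2)cc1` — 200 nM

Of the two numbers shown, compound 2 stands at the lower one, with compound 1 higher by a margin beyond the scatter. Within the data shown here, no single-change pair among the measured compounds gives a calibrated step.

Compound 3 `CCCCCN1CCC(COC(c2ccccc2)c2ccccc2)CC1` differs from compound 2 as follows: ethyl in place of 4-methylphenyl on a saturated chain carbon, three bonds along the chain from an amine nitrogen in a ring. With the ring removed from the chain, the number is expected to rise beyond the scatter, a step from compound 2 to compound 3 of a 7.5-fold higher number from compound 2 to compound 3 (0.88 log units; beyond the scatter). For compound 3 the estimate is 1500 nM, within 400 nM to 6000 nM.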

Compound 3, half-maximal inhibitory concentration: 10800 nM
Compound 3: middle estimate off by 7.2-fold (0.86 log units), on the low side, and the stated range ends below it.
By their numbers in this assay, from the lowest: compound 2; then compounds 1 and 3 (each within the scatter of the next).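

In this assay, among these compounds, ethyl in place of 4-methylphenyl, which reads as 3-(4-methylphenyl)propyl to pentyl, gives a 54-fold higher number from compound 2 to compound 3 (1.73 log units; beyond the scatter), the first calibrated step and a large one. This position on the chain therefore does not tolerate losing the 4-methylphenyl group when the rest of compound 2 stays the same. No measured evidence bears on the reason for this step.

The compounds shown leave open whether the aromatic ring or simply the carbon count matters. A cyclohexyl group or a longer chain such as heptyl in this place would separate the two.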